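Bromo to Trifluoromethyl: Estimating a Fourth Compound

A few compounds are considered here, and "the series" means these few. Any claim that something is new, unique, unknown or untested is made for them only; others in the source may bear on it.

Measured so far in an ADME assay on isolated protein for inhibition of Amine oxidase [flavin-containing] B (Homo sapiens) (a higher number here means a weaker inhibitor, a lower number a stronger inhibitor), are compound 1, compound 2 and compound 3. Compound 1, `C#CCNC1CCc2c(SCc3ccc(Br)cc3)cccc21`, gives 488 nM. Compound 3, `C#CCNC1CCc2c(SCCc3cccc(Br)c3)cccc21`, gives 620 nM in this assay, and compound 2, `C#CCNC1CCc2c(SCCc3cccc(C(F)(F)F)c3)cccc21`, gives 280 nM. The values of compound 1 and compound 3 lie within the usual scatter of each other, as do those of compound 1 and compound 2, so no order can be read among them.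

Compound 3 and compound 2 differ in a single place: trifluoromethyl in place of bromo on an aromatic carbon. This change brought a 2.2-fold lower number from compound 3 to compound 2 (0.35 log units; beyond the scatter), a modest but real move toward stronger inhibition.

Compound 4, `C#CCNC1CCc2c(SCc3ccc(C(F)(F)F)cc3)cccc21`, has not yet been measured. It relates to compound 1 as compound 2 relates to compound 3: trifluoromethyl in place of bromo on an aromatic carbon. The difference between the core of compound 1 and the core of compound 3 is not broken down here. The two changes are the same kind of change rather than the same: in compound 2 the new group stands meta to a large group, in compound 4 it stands para to a large group.

Within the data shown here, the expectation rests on the one earlier example, which gave a 2.2-fold lower number from compound 3 to compound 2 (0.35 log units; beyond the scatter), tempered by the unbroken-down core difference and the different place. On that basis the step expected here is a 2.0-fold lower number from compound 1 to compound 4 (0.29 log units; within the scatter). Compound 4 is therefore estimated at 250 nM, expected to fall between 120 nM and 550 nM.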

Compound 4, half-maximal inhibitory concentration: 930 nM
Compound 4: the middle estimate sits 3.7-fold (0.57 log units) below what was measured, and the stated range ends below it.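

In this assay, putting trifluoromethyl in place of bromo on the core of compound 1 gave a 1.9-fold higher number from compound 1 to compound 4 (0.28 log units; within the scatter), and on this core the swap therefore cannot be told apart from no effect at all. Set beside the earlier pair, the swap does not behave as a fixed step that can simply be carried from one core to another in this series: the same change on two cores in this assay, a 2.2-fold lower number (0.35 log units; beyond the scatter) from compound 3 to compound 2 and a 1.9-fold higher number (0.28 log units; within the scatter) from compound 1 to compound 4, 4.2-fold (0.63 log units) apart, beyond the scatter of two such steps What this does not show is which difference matters, since the two pairs differ both in the core and in where the trifluoromethyl stands, para to a large group in compound 4, and two pairs give no rule for any further core.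

The compounds shown leave open what the same swap does when only its place changes on a single core, a comparison that would separate the two explanations. They also leave open whether other replacements for bromo, such as chloro or methoxy, would track the step seen on the core of compound 3 or the one seen on the core of compound 1.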